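Urea to Amide on a Pyrazole Scaffold: Expected Cell Response

The source may hold more compounds than are shown below. What is called first, only, known or untested is meant among the compounds shown, and "the series" means these compounds.

Compound 1, `COc1cc(Cl)cc(-c2nn(-c3cccc(NC(=O)Nc4ccc(Cl)c(Cl)c4)c3)cc2-c2ccncc2)c1`, carries a urea linking two aromatic rings. In a functional assay on HOP-62 cells (Homo sapiens) for inhibition, read by sulforhodamine B assay, with a stated time of 48 h, tested at 0.01 uM (on this read-out higher numbers stand for a weaker effect at the one concentration tested and lower numbers for a stronger effect), compound 1 gives 92%. Compound 2, `COc1cc(Cl)cc(-c2nn(-c3cccc(NC(=O)Nc4cccc(C(F)(F)F)c4)c3)cc2-c2ccncc2)c1`, differs only in the ring on the far side of the urea, and in this assay compound 2 gives 96%. The step of a number 4 percentage points higher from compound 1 to compound 2 (within the scatter) is too small to speak of as a change, so compound 2 stands alongside compound 1 with both numbers indicating a weak effect at the single concentration tested.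

Compound 3, `COc1cc(Cl)cc(-c2nn(-c3cccc(NC(=O)c4cccc(C(F)(F)F)c4)c3)cc2-c2ccncc2)c1`, is not yet measured. It differs from compound 2 in one place: 3-(trifluoromethyl)phenyl in place of (3-(trifluoromethyl)phenyl)amino on a carbonyl carbon. In other words, the urea becomes an amide, with one nitrogen and one hydrogen-bond donor removed.

Among the compounds with values here, no measured step bears directly on this kind of change; the only step seen, from compound 1 to compound 2, swaps one aryl ring for another while keeping the urea intact and stays within the scatter. With nothing in the data pointing toward a stronger effect, compound 3 is expected to sit near compound 2, with a number 2 percentage points lower from compound 2 to compound 3 (within the scatter) within the scatter. The estimate for compound 3 in this assay is 94%, between 82% and 104%.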

Compound 3, a percentage reported as activity, at one concentration (the size of the read-out at that concentration, not a potency): 104%
Estimate against measurement, compound 3: 10 percentage points below; measured number inside the range.
By their numbers in this assay, from the lowest: compounds 1, 2 and 3 (each within the scatter of the next, the first and the last beyond it).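

Replacing the (3-(trifluoromethyl)phenyl)amino group on the carbonyl carbon with 3-(trifluoromethyl)phenyl turns the urea into an amide, and in this assay this gives a number 8 percentage points higher from compound 2 to compound 3 (within the scatter) and so cannot be told apart from no change at the single concentration tested. Within the data shown here, measured against the other urea, the same exchange brings in a different ring as well, and the result is a number 12 percentage points higher from compound 1 to compound 3 (beyond the scatter) as the only step here that clears the scatter, although it remains modest and moves toward a weaker effect. Nothing measured here explains either step.

What the compounds shown leave open is whether any group on the carbonyl carbon can produce a clear effect in this cell assay at this low concentration, for example a carboxylic acid or an amine on the ring, or a longer chain in place of 3-(trifluoromethyl)phenyl. They also leave open whether the urea and the amide would separate at higher concentrations, where a full concentration series could show the size of the effect at each concentration rather than at one.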